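The source may report more compounds than this note shows. Statements on the series, on what has been measured and on what is new or still open speak of the compounds shown alone.

Three measured compounds share a common core and differ in the aryl group carried on a nitrogen on an aromatic ring, and in one case in other parts of the molecule as well. Compound 1 `Cc1nc(Nc2ccccc2)sc1C(=O)/C=C/c1ccc(Cl)cc1` carries an anilino group. In a functional assay on Bel-7402 cells (Homo sapiens) for cytotoxicity, read by MTT assay (on this read-out lower numbers stand for stronger inhibition and higher numbers for weaker inhibition), compound 1 gives > 25000 nM, which is a limit of the assay and not a number. Compound 2 `Cc1nc(Nc2ccc(Cl)c(Cl)c2)sc1C(=O)/C=C/c1ccc(Cl)cc1` carries a (3,4-dichlorophenyl)amino group at the same place. In this assay compound 2 gives > 25000 nM, again a limit rather than a number. Compound 3 `COc1cc(/C=C/C(=O)c2sc(Nc3ccc(Cl)c(Cl)c3)nc2C)cc(OC)c1OC` keeps the (3,4-dichlorophenyl)amino group but differs from compound 2 in more than one place; the difference between the two cores is not broken down here. In this assay compound 3 gives > 25000 nM, once more a limit. All three values sit at the limit of > 25000 nM in this assay, at which 3 of the 3 values shown sit.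

The change from compound 2 to compound 1 is phenyl in place of 3,4-dichlorophenyl on a nitrogen on an aromatic ring, and the step it made is a step that the two limits leave unreadable from compound 2 to compound 1. The unmeasured compound 4 `COc1cc(/C=C/C(=O)c2sc(Nc3ccccc3)nc2C)cc(OC)c1OC` stands to compound 3 as compound 1 stands to compound 2, through the same change, (phenyl in place of 3,4-dichlorophenyl on a nitrogen on an aromatic ring), at a place described in the same words. In this assay the expected step is a step that the limit leaves unreadable from compound 3 to compound 4. This expectation rests on compound 3 sitting at the limit of > 25000 nM in this assay, at which 3 of the 3 values shown sit, and on the same change elsewhere giving a step that two limits leave unreadable. Compound 4 is therefore estimated at 40000 nM, within a range from 15000 nM to 150000 nM, and most likely only a limit will again be reported.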

Compound 4, half-maximal inhibitory concentration: > 25000 nM
Compound 4 ended at the assay's limit; the forecaster's own chance of this, stated with the estimate: 85%; the middle value is on the limit's open side.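

Compound 3 and compound 4 both stand at a limit and not at a number, so no new step can be read between them: the limit of > 25000 nM in this assay, at which 4 of the 4 values shown sit.

The compounds shown leave open how strongly any of them acts in this assay, and whether the change from 3,4-dichlorophenyl to phenyl on the nitrogen makes any difference there.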